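The source may hold more compounds than are shown below. What is called first, only, known or untested is meant among the compounds shown, and "the series" means these compounds.

Series notes. The shared core of compound 1 `CCNC(=O)[C@H]1O[C@@H](n2cnc3c(NNC(=O)c4ccccc4)nc(Cl)nc32)[C@H](O)[C@@H]1O` carries a benzoyl hydrazine; in an assay on CHO cells for displacement of a labelled ligand from adenosine receptor A1 (Homo sapiens) (a higher number here means a weaker inhibitor, a lower number a stronger inhibitor), compound 1 gives > 5000 nM, which is a limit of the assay. Compound 2 `CCNC(=O)[C@H]1O[C@@H](n2cnc3c(NNC(=O)c4ccc[nH]4)nc(Cl)nc32)[C@H](O)[C@@H]1O` gives 610 nM in this assay. Compound 3 `CCNC(=O)[C@H]1O[C@@H](n2cnc3c(NNC(=O)c4cc(C)on4)nc(Cl)nc32)[C@H](O)[C@@H]1O` gives > 5000 nM in this assay, again a limit. Compound 3 therefore stands at the limit of > 5000 nM in this assay, at which 2 of the 3 values shown sit, with no number of its own. Compound 4 `CCNC(=O)[C@H]1O[C@@H](n2cnc3c(NNC(=O)c4cc(-c5ccccc5)on4)nc(Cl)nc32)[C@H](O)[C@@H]1O` differs from it by phenyl in place of methyl on an aromatic carbon. For the measured compounds named here, none of the measured steps touches this position: an at least 8.1-fold lower number from compound 1 to compound 2 (0.91 log units; beyond the scatter) and an at least 8.1-fold higher number from compound 2 to compound 3 (0.91 log units; beyond the scatter) exchange the whole group on the carbonyl carbon, and a step that the two limits leave unreadable from compound 1 to compound 3 runs between two limits. No direction for the present change can be read from them, so a step within the scatter is expected, a step that the limit leaves unreadable from compound 3 to compound 4. For compound 4 the expected value in this assay is 8000 nM, in the range 2000 nM to 30000 nM, most probably reported again as a limit.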

Compound 4, inhibition constant: > 5000 nM
Compound 4: a limit, no number; the forecaster's own chance of this, stated with the estimate: 70%; the middle value lies beyond the limit too.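

With phenyl in place of methyl on the aromatic carbon next to the ring oxygen, compound 4 also gives only a limit in this assay: the limit of > 5000 nM in this assay, at which 3 of the 4 values shown sit. The larger group at this position thus gives no number, and exchange of the 1H-pyrrol-2-yl group for 5-phenyl-1,2-oxazol-3-yl gives an at least 8.1-fold higher number from compound 2 to compound 4 (0.91 log units; beyond the scatter). The steps to compound 4 from compound 1 and from compound 3 run between two limits and cannot be read.

Still open, going by these compounds, is what an amine or a carboxylic acid on this aromatic carbon would give. On these data alone, how far compound 4 lies past its limit also remains unknown.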